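From Fluoro to Methyl on the Shared Core

The compounds below may be only part of what the source reports. "The series", "measured", "known", "first", "only" and "open" are said of these compounds alone.

Of the compounds shown here, two with the shared core have been measured in an in vivo ADME assay on the whole organism (strain BALB/c) for pharmacokinetics, with Mus musculus as the target, read by LC-MS, at a dose of 5 mg/kg by the oral route; on this read-out higher numbers stand for higher oral bioavailability and lower numbers for lower oral bioavailability. In this assay, compound 1 (`COCCNS(=O)(=O)c1ccc(C)c(C#Cc2cc(Cl)ccc2OCC(=O)O)c1`) gives 33% and compound 2 (`CS(=O)(=O)c1ccc(F)c(C#Cc2cc(Cl)ccc2OCC(=O)O)c1`) gives 24%. These two numbers lie within the usual scatter of each other, so compound 2 stands level with compound 1.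

Compound 3 (`Cc1ccc(S(C)(=O)=O)cc1C#Cc1cc(Cl)ccc1OCC(=O)O`) differs from compound 2 in one place: methyl in place of fluoro on an aromatic carbon. It has methyl in place of fluoro on an aromatic carbon, para to a methylsulfonyl group. Within the data shown here, no measured pair shows this change alone, so its size is not known directly. Compound 1 also carries a methyl group and gives 33%, but it differs from compound 3 elsewhere too. A small upward move that stays within the scatter is expected, with an estimated step of a number 4 percentage points higher from compound 2 to compound 3 (within the scatter). For compound 3 the estimate is 28%, with an expected range of 14% to 42%.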

Compound 3, oral bioavailability: 49%
Beside the measured number, compound 3's estimate is 21 percentage points below it, and the stated range ends below it.
By their numbers in this assay, from the lowest: compounds 2 and 1 (each within the scatter of the next); then compound 3.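

In this assay the swap of fluoro for methyl on an aromatic carbon, para to a methylsulfonyl group, can now be read on its own as a number 25 percentage points higher from compound 2 to compound 3 (beyond the scatter), so this position matters far more than the small move expected of a one-atom change. The sulfonyl sulfur matters as well: methyl in place of (2-methoxyethyl)amino there gives a number 16 percentage points higher from compound 1 to compound 3 (beyond the scatter), which leaves compound 3 the highest of the three on oral bioavailability. Nothing available accounts for either step.

As far as these compounds go, it remains open whether chloro, methoxy or ethyl at the same aromatic carbon would match methyl or go beyond it. From the compounds shown here alone, it is also open whether an amine or a longer chain on the sulfonyl sulfur would hold the level of compound 3.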